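A few compounds are considered here, and "the series" means these few. Any claim that something is new, unique, unknown or untested is made for them only; others in the source may bear on it.

Measured compounds and results:
- compound 1, `CCN(c1ccc(C#N)c(Cl)c1)c1cc(-c2ccncc2)ccc1C`: 3580 nM
- compound 2, `CCN(c1ccc(C#N)c(Cl)c1)c1cc(-c2ccccc2)ccc1C`: "not determined" (no result reported)
- compound 3, `CCN(c1ccc(C#N)c(Cl)c1)c1cc(C2=CCCCC2)ccc1C`: "not determined" (no result reported)

In a functional assay on PC-3 cells (Homo sapiens) for antiproliferative activity, read by CCK-8 assay, with a stated time of 6 days (a lower number here means a stronger inhibitor, a higher number a weaker inhibitor), compound 1 gives 3580 nM. For compound 2 the entry in this assay reads "not determined" (no result reported). For compound 3 the entry in this assay likewise reads "not determined" (no result reported). Compound 3 therefore stands without a single number in this assay, and the only numerical anchor in the series is the value of compound 1. For the measured compounds named here, no step between two measured compounds is available, so nothing is known about how much any change on the shared core moves the result.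

The next compound is compound 4, `CCN(c1ccc(C#N)c(Cl)c1)c1cc(-n2cccn2)ccc1C`. It differs from compound 3 in one place: 1H-pyrazol-1-yl in place of cyclohex-1-en-1-yl on an aromatic carbon. Going by the values given here, with no measured step to lean on, the direction of the change from compound 3 to compound 4 in this assay cannot be read from the data; the step is as likely to fall within the scatter as beyond it, in either direction. The estimate for compound 4 in this assay rests on compound 1 at 3580 nM as the sole measured point of the series and is therefore given a wide range: compound 4 is expected at about 3000 nM, between 700 nM and 13000 nM.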

Compound 4, half-maximal inhibitory concentration: 15700 nM
Compound 4: the middle estimate sits 5.2-fold (0.72 log units) below what was measured, outside the stated range (above it).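

In this assay, for the compounds shown here, the exchange of pyridin-4-yl for 1H-pyrazol-1-yl on this aromatic carbon gives a 4.4-fold higher number from compound 1 to compound 4 (0.64 log units; beyond the scatter) and provides the first measured step, showing that the result responds to the group at this position. Compound 2 and compound 3 carry no number, so the steps that involve them cannot be read, and the cyclohex-1-en-1-yl to 1H-pyrazol-1-yl change gives no measured effect. Nothing measured in the material at hand explains the step between the pyridin-4-yl and 1H-pyrazol-1-yl compounds.

Going by these compounds alone, with numbers for only two groups at this position, the step rests on a single pair and no trend across groups can be drawn. As far as these compounds go, whether another pyridine isomer, an imidazol-1-yl ring, a morpholine, a primary amine or a carboxylic acid at this position would give a lower or higher number than compound 1 remains open.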